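The source may hold more compounds than are shown below. What is called first, only, known or untested is meant among the compounds shown, and "the series" means these compounds.

Series notes. All compounds share one core bearing an amide whose nitrogen carries a varied aryl group. Compound 1 `Cc1ccc(NC(=O)COc2ccc3cc(/C=C4/SC(=O)NC4=O)ccc3c2)cc1Cl` gives in an assay on isolated protein for inhibition of histone deacetylase 4 (Homo sapiens), with a stated time of 1 h (a higher number here means a weaker inhibitor, a lower number a stronger inhibitor), a value of 1100 nM. Compound 2 `O=C(COc1ccc2cc(/C=C3/SC(=O)NC3=O)ccc2c1)Nc1ccc(Br)cc1` gives in this assay a value of 2900 nM, and compound 3 `O=C(COc1ccc2cc(/C=C3/SC(=O)NC3=O)ccc2c1)Nc1cc(Cl)cc(C(F)(F)F)c1` gives in this assay a value of 4000 nM. Among the three numbers that of compound 3 is the highest; against compound 2 the difference is a 1.4-fold higher number from compound 2 to compound 3 (0.14 log units; within the scatter), which is within the scatter, while against compound 1 it is a 3.6-fold higher number from compound 1 to compound 3 (0.56 log units; beyond the scatter). The step of a 2.6-fold higher number from compound 1 to compound 2 (0.42 log units; beyond the scatter) is likewise modest. Compound 4 `Cc1cccc(NC(=O)COc2ccc3cc(/C=C4/SC(=O)NC4=O)ccc3c2)n1` is not yet measured. It differs from compound 3 at the same place that varies across the measured set: 6-methylpyridin-2-yl in place of 3-chloro-5-(trifluoromethyl)phenyl on an amide-type nitrogen. For the measured compounds named here, the steps that bear on this change are the swaps at the amide nitrogen, a 3.6-fold higher number from compound 1 to compound 3 (0.56 log units; beyond the scatter) and a 1.4-fold higher number from compound 2 to compound 3 (0.14 log units; within the scatter); all three measured groups at this place fall in a narrow band, and none of them is a ring with a hetero atom, so the direction of the step cannot be drawn from the data. Since every swap at this nitrogen has been modest, compound 4 is expected to give a number of similar order, estimated at 2500 nM with a range from 800 nM to 8000 nM. This estimate means an expected step of a 1.6-fold lower number from compound 3 to compound 4 (0.20 log units; within the scatter), close to the scatter.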

Compound 4, half-maximal inhibitory concentration: 1100 nM
For compound 4 the middle estimate is 2.3-fold (0.36 log units) above the measured one; measured number inside the range.
By their numbers in this assay, from the lowest: compounds 1 and 4 (each within the scatter of the next); then compounds 2 and 3 (each within the scatter of the next).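

For the compounds shown here, the 6-methylpyridin-2-yl group is the first ring with a hetero atom seen on the amide-type nitrogen, and in this assay it gives a 3.6-fold lower number from compound 3 to compound 4 (0.56 log units; beyond the scatter) and a 2.6-fold lower number from compound 2 to compound 4 (0.42 log units; beyond the scatter), while the comparison with the best earlier aryl group shows no change at the digits printed from compound 1 to compound 4 (within the scatter). This position therefore accepts a ring nitrogen and a group of fewer heavy atoms than 3-chloro-5-(trifluoromethyl)phenyl, and the halogen carried by compounds 1, 2 and 3 is not required to reach the low end of the series; compounds 1 and 4 both carry a methyl group, whereas compounds 2 and 3 carry none, though this observation rests on four compounds whose rings differ in other ways too. No data are available that explain the step.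

On these data alone, the separate contributions of the ring nitrogen and the methyl group remain open, and an unsubstituted pyridin-2-yl or plain phenyl ring at this place would help to separate them. Also open, as far as these compounds go, is how this position responds to a ring bearing an amine or a carboxylic acid.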